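The compounds below may be only part of what the source reports. "The series", "measured", "known", "first", "only" and "open" are said of these compounds alone.

Measured in a functional assay on HepG2 cells (Homo sapiens) for cytotoxicity, read by WST assay, with a stated time of 24 h; on this read-out higher numbers stand for lower toxicity in this test and lower numbers for higher toxicity in this test:
- compound 1 `Cc1cc(-c2ccc3cc(CO)ccc3c2)ccc1O`: > 32 ug/mL (a limit of the assay)
- compound 2 `CCCCCCCCCc1cc(-c2ccc3cc(CO)ccc3c2)ccc1O`: 7.25 ug/mL
- compound 3 `CCCCCCCc1cc(-c2ccc3cc(CO)ccc3c2)ccc1O`: 3.61 ug/mL

Compound 3 gives 3.61 ug/mL, which lies within the scatter of compound 2, as a 2.0-fold lower number from compound 2 to compound 3 (0.30 log units; within the scatter) shows. Compound 1 has only a limit, > 32 ug/mL. Compound 4 `CC(C)(C)c1cc(-c2ccc3cc(CO)ccc3c2)ccc1O` carries a different group, tert-butyl in place of heptyl on an aromatic carbon, ortho to a hydroxy group. Among the compounds with values here, two measured steps bear on this change, an at least 8.8-fold lower number from compound 1 to compound 3 (0.94 log units; beyond the scatter) and an at least 4.4-fold lower number from compound 1 to compound 2 (0.64 log units; beyond the scatter), and both lie beyond the scatter. Both add a long chain to compound 1, whereas tert-butyl is the smaller group, so a partial move back towards compound 1 is expected. The expected change is a 3.3-fold higher number from compound 3 to compound 4 (0.52 log units; beyond the scatter), a higher number beyond the scatter. The estimate for compound 4 is 12 ug/mL, with an expected range of 5 ug/mL to 32 ug/mL.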

Compound 4, concentration lethal to 50% of the cells: 7.5 ug/mL
Estimate against measurement, compound 4: 1.6-fold (0.20 log units) above; the measured number falls inside the stated range.
By their numbers in this assay, from the lowest: compounds 3, 2 and 4 (each within the scatter of the next, the first and the last beyond it). At a limit, above all of these: compound 1.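

A long chain is not needed at this position for a lower number in this assay, since tert-butyl in place of methyl already gives a clear drop (an at least 4.2-fold lower number from compound 1 to compound 4 (0.63 log units; beyond the scatter)). That drop is measured against a limit for compound 1: the limit of > 32 ug/mL in this assay, at which 1 of the 4 values shown sits. Heptyl gives a modestly lower number than tert-butyl (a 2.1-fold higher number from compound 3 to compound 4 (0.32 log units; beyond the scatter)), whereas tert-butyl and nonyl cannot be told apart (a 1.0-fold higher number from compound 2 to compound 4 (0.01 log units; within the scatter)), so chain size alone does not set the order here.

Still open, going by these compounds, is how an ethyl group, an amine or a carboxylic acid at this position would behave. What lies behind these differences also stays open.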